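This account rests on a few compounds, and the source may have more. Where it says the series, first, only, none or still open, it means among the compounds named here.

Working notes on the series. Compound 1 `COCCNc1nc(C)cc2c1c(N)nn2C` gives -4% in an assay on isolated protein for inhibition of ribosomal protein S6 kinase alpha-1 (Homo sapiens), read by mobility shift assay, tested at 30 uM (on this read-out lower numbers stand for less inhibition and higher numbers for more inhibition at the one concentration tested (going by the name of the read-out)), and compound 2 `Cc1cc2c(cn1)c(N)nn2C` gives 1% in the same assay; the step of a number 5 percentage points higher from compound 1 to compound 2 (within the scatter) leaves the two values within the scatter of each other, so neither stands apart. Compound 3 `Cc1cc2[nH]nc(N)c2cn1` differs from compound 2 by hydrogen in place of methyl on an aromatic nitrogen. Among the measured compounds shown here, no measured step concerns this change; the only step on record, from compound 1 to compound 2, involved a different group and stayed within the scatter. The step of a number 1 percentage points lower from compound 2 to compound 3 (within the scatter) is therefore expected to remain within the scatter, with no clear direction. Compound 3 is estimated at 0%, within -12% to 12%.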

Compound 3, a percentage reported as inhibition, at one concentration (the size of the read-out at that concentration, not a potency): 11%
For compound 3 the middle estimate is 11 percentage points below the measured one, and the stated range covers the measured number.
By their numbers in this assay, from the lowest: compounds 1, 2 and 3 (each within the scatter of the next, the first and the last beyond it).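

In this assay, among the compounds shown here, hydrogen in place of methyl on the aromatic nitrogen gives a number 10 percentage points higher from compound 2 to compound 3 (within the scatter) as the first measured step at this position. The methyl on this nitrogen is therefore not needed for the small read-out seen here, although the step does not establish a direction. No supporting data bear on this result. Still open, from the compounds shown here alone, is whether ethyl or a longer chain on this aromatic nitrogen would move the read-out beyond the scatter, and whether a terminal amine on such a chain would do so.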